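This account rests on a few compounds, and the source may have more. Where it says the series, first, only, none or still open, it means among the compounds named here.

Compound 1, `CCOC(=O)c1oc2ccc(N(Cc3ccccc3)S(=O)(=O)c3cccc(Br)c3)cc2c1C`, gives > 40000 nM in a functional assay on HCT-116 cells (Homo sapiens) for inhibition, read by MTT assay, with a stated time of 72 h (on this read-out lower numbers stand for stronger inhibition and higher numbers for weaker inhibition), which is a limit of the assay rather than a number. Compound 2, `CCOC(=O)c1oc2ccc(N(Cc3ccccc3)S(=O)(=O)c3ccc(C)cc3)cc2c1C`, gives > 40000 nM in this assay, again a limit. Compound 3, `CCOC(=O)c1oc2ccc(N(Cc3ccccc3)S(=O)(=O)c3ccc([N+](=O)[O-])cc3)cc2c1C`, gives > 40000 nM in this assay, also a limit.

All three compounds share one core and differ only in the group on the sulfonyl sulfur. Compound 3 thus stands where the other two stand: all three values sit at the limit described by the limit of > 40000 nM in this assay, at which 3 of the 3 values shown sit, so none of the three can be told apart from another. The steps among them, a step that the two limits leave unreadable from compound 1 to compound 2, a step that the two limits leave unreadable from compound 1 to compound 3 and a step that the two limits leave unreadable from compound 2 to compound 3, cannot be read in size; both ends of each are limits.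

Compound 4, `CCOC(=O)c1oc2ccc(N(Cc3ccccc3)S(=O)(=O)c3ccc(Cl)cc3)cc2c1C`, is not yet measured. It differs from compound 3 by chloro in place of nitro on an aromatic carbon. Among the compounds with values here, the steps that bear on this change are the three above, all unreadable; they show only that every change of the group on the sulfonyl sulfur so far has left the compound at the limit. The expected step is therefore a step that the limit leaves unreadable from compound 3 to compound 4, none beyond the scatter. Compound 4 is expected to give about 60000 nM in this assay, within a range from 20000 nM to 200000 nM, most likely again as a limit.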

Compound 4, half-maximal inhibitory concentration: 4860 nM
Compound 4: middle estimate off by 12-fold (1.09 log units), on the high side; measured number below the stated range.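

Chloro is the first group in this series on that aromatic carbon to give a readable number in this assay, so the group on the sulfonyl sulfur can change the result after all: chloro in place of nitro gives an at least 8.2-fold lower number from compound 3 to compound 4 (0.91 log units; beyond the scatter). Chloro in place of methyl gives an at least 8.2-fold lower number from compound 2 to compound 4 (0.91 log units; beyond the scatter), and 4-chlorophenyl in place of 3-bromophenyl gives an at least 8.2-fold lower number from compound 1 to compound 4 (0.91 log units; beyond the scatter). The steps among compound 1, compound 2 and compound 3 remain unreadable, and only compound 4 has left the limit: the limit of > 40000 nM in this assay, at which 3 of the 4 values shown sit.

Compound 1 differs from compound 4 in both the halogen and where it sits, so the compounds shown cannot separate those two changes. As far as these compounds go, how a fluoro, a methoxy or an amine would compare with chloro on that same aromatic carbon also stays open.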